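Thiophen-2-yl for phenyl, tested on a second core

The compounds below may be only part of what the source reports. "The series", "measured", "known", "first", "only" and "open" are said of these compounds alone.

Three measured compounds share one set of atoms. Compound 1 `Oc1cccc(-c2cc(-c3ccccc3)cc(-c3ccccc3)n2)c1` and compound 2 `Oc1cccc(-c2cc(-c3ccccc3)cc(-c3cccs3)n2)c1` differ in one place; compound 3 `Oc1cccc(-c2cc(-c3ccccc3)nc(-c3ccccc3)c2)c1` has the same atoms as compound 1 joined differently, and the difference between the two cores is not broken down here. In a functional assay on DU-145 cells (Homo sapiens) for cytotoxicity, read by ELISA, with a stated time of 2 days (on this read-out higher numbers stand for weaker inhibition and lower numbers for stronger inhibition), compound 1 gives 18000 nM. In this assay compound 2 gives 18900 nM. In this assay compound 3 gives 17900 nM. The change from compound 1 to compound 2 is thiophen-2-yl in place of phenyl on an aromatic carbon; it made a 1.1-fold higher number from compound 1 to compound 2 (0.02 log units; within the scatter). The values of compound 3 and compound 1 stand within the scatter of each other, as do those of compound 3 and compound 2, so nothing separates the three.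

Compound 4 `Oc1cccc(-c2cc(-c3ccccc3)nc(-c3cccs3)c2)c1` has not yet been measured. It arises from compound 3 by thiophen-2-yl in place of phenyl on an aromatic carbon, the same change as that from compound 1 to compound 2, made at a place described in the same words. The expectation for compound 4 therefore rests on a single precedent on a core whose value sits within the scatter of compound 3. The step from compound 3 to compound 4 is expected to be a 1.1-fold higher number from compound 3 to compound 4 (0.03 log units; within the scatter), because a 1.1-fold higher number from compound 1 to compound 2 (0.02 log units; within the scatter) stayed within the scatter. In this assay compound 4 is expected to give 19000 nM, with a plausible range from 9000 nM to 40000 nM. One pair is a thin basis; whether the second core behaves alike is what the measurement will show.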

Compound 4, half-maximal inhibitory concentration: 19700 nM
Compound 4: middle estimate off by 1.0-fold (0.02 log units), on the low side, and the stated range covers the measured number.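

In this assay, thiophen-2-yl in place of phenyl on the core of compound 3 gave a 1.1-fold higher number from compound 3 to compound 4 (0.04 log units; within the scatter), and this step agrees with its precedent on the core of compound 1: the same change on two cores in this assay, a 1.1-fold higher number (0.02 log units; within the scatter) from compound 1 to compound 2 and a 1.1-fold higher number (0.04 log units; within the scatter) from compound 3 to compound 4, 1.0-fold (0.02 log units) apart, within the scatter of two such steps. The swap therefore behaves alike on both cores shown, with a step within the scatter each time, so for these two pairs the outcome on one core would have served as a fair guide to the outcome on the other. Among the compounds shown here, this does not show that an effect of real size would carry from one core to the other, since neither step is separable from the scatter, and agreement between two near-null steps rests on only two pairs at a single place in a single cell assay.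

The compounds shown carry only phenyl or thiophen-2-yl at this place, so it remains open whether an amine, a carboxylic acid or a longer alkyl chain there would move the number beyond the scatter on either core, and whether such a step would then match between the cores. Also open, on these data alone, is what replacing the hydroxyl of the 3-hydroxyphenyl group, for instance with a methoxy group or an amine, would do on each core.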